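Swapping the Methyl for a Hydroxyl on the Aryl Ring

A few compounds are considered here, and "the series" means these few. Any claim that something is new, unique, unknown or untested is made for them only; others in the source may bear on it.

Compound 1 `N#CC1=C(N)N(c2ccc(S(N)(=O)=O)cc2)C2=C(CCCC2)C1c1ccccc1` and compound 2 `Cc1ccc(C2C(C#N)=C(N)N(c3ccc(S(N)(=O)=O)cc3)C3=C2CCCC3)cc1` share one core and differ only in a methyl in place of a hydrogen on an aromatic carbon. In a functional assay on Ehrlich cells (Mus musculus) for cytotoxicity, read by trypan blue exclusion, with a stated time of 2 h, tested at 100 ug/mL (a lower number here means a weaker effect, a higher number a stronger effect of the compound at the concentration tested), compound 1 gives 30%, whereas compound 2 gives 90%. Among the measured compounds shown here, that step, a number 60 percentage points higher from compound 1 to compound 2 (beyond the scatter), is the only one recorded, and it places compound 2 at the top of the two numbers known, with compound 1 as its nearest neighbour, well beyond the scatter. Compound 3 `N#CC1=C(N)N(c2ccc(S(N)(=O)=O)cc2)C2=C(CCCC2)C1c1ccccc1O` has not been measured yet. It differs from compound 2 in one place: 2-hydroxyphenyl in place of 4-methylphenyl on a saturated ring carbon. For the measured compounds named here, the single measured step bears on this change only in part, because a number 60 percentage points higher from compound 1 to compound 2 (beyond the scatter) shows what the methyl adds, and in compound 3 that methyl is gone again, while the hydroxyl that enters has no counterpart among the measured compounds. Losing the methyl alone would be expected to pull the number back toward compound 1, so a drop beyond the scatter is expected, a number 40 percentage points lower from compound 2 to compound 3 (beyond the scatter), with no basis to say whether the hydroxyl softens or deepens it. Compound 3 is therefore estimated at 50% in this assay, with a range from 20% to 85%.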

Compound 3, a percentage reported as activity, at one concentration (the size of the read-out at that concentration, not a potency): 100%
Compound 3: the middle estimate sits 50 percentage points below what was measured; measured number outside the range, above it.
By their numbers in this assay, from the lowest: compound 1; then compounds 2 and 3 (each within the scatter of the next).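

Among the compounds shown here, the step of a number 10 percentage points higher from compound 2 to compound 3 (within the scatter) in this assay means that 2-hydroxyphenyl and 4-methylphenyl cannot be told apart at this saturated ring carbon, so the methyl is not the only group on the aryl ring that goes with a high number. The hydroxy group alone gives a number 70 percentage points higher from compound 1 to compound 3 (beyond the scatter) on the same core, a large step that stands beside the earlier a number 60 percentage points higher from compound 1 to compound 2 (beyond the scatter) for the methyl, and among these three compounds only the unsubstituted phenyl of compound 1 gives a low number, with none going against that pattern. Nothing shown here explains why either group has this effect on the plain phenyl ring.

The two groups also sit at different places on the aryl ring, so what comes from the group and what comes from its place stays unresolved until 4-hydroxyphenyl and 2-methylphenyl can be compared, and the same holds for other groups on that ring, such as an amine or a carboxylic acid. All of these readings come from one concentration, which leaves open whether compound 2 and compound 3 would still look alike at lower concentrations.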